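The compounds below may be only part of what the source reports. "The series", "measured", "known", "first", "only" and "open" are said of these compounds alone.

Measured compounds:
- compound 1 `Oc1ccccc1/C=N/c1nnc(SCc2nnc(-c3ccc(F)cc3)o2)s1` — 13100 nM in a functional assay on SMMC-7721 cells (Homo sapiens) for inhibition, read by CCK-8 assay; on this read-out higher numbers stand for weaker inhibition and lower numbers for stronger inhibition
- compound 2 `Oc1ccccc1/C=N/c1nnc(SCc2nnc(-c3ccccc3Br)o2)s1` — 6780 nM
- compound 3 `Cc1ccc(-c2nnc(CSc3nnc(/N=C/c4ccccc4O)s3)o2)cc1` — 37100 nM

Among these three numbers compound 1 stands second highest; its nearest neighbour is compound 2 with a 1.9-fold lower number from compound 1 to compound 2 (0.29 log units; within the scatter), and the furthest is compound 3 with a 2.8-fold higher number from compound 1 to compound 3 (0.45 log units; beyond the scatter). The unmeasured compound 4 `O=[N+]([O-])c1ccc(-c2nnc(CSc3nnc(/N=C/c4ccccc4O)s3)o2)cc1` is reached from compound 1 by a single change at the far aryl ring: nitro in place of fluoro on an aromatic carbon.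

Among the compounds with values here, no measured step replaces fluoro with nitro, so the bearing evidence is indirect. Within the data shown here, the only comparison at the same aromatic carbon is a 2.8-fold higher number from compound 1 to compound 3 (0.45 log units; beyond the scatter), a modest move toward weaker inhibition; the ring-level swap a 5.5-fold higher number from compound 2 to compound 3 (0.74 log units; beyond the scatter) is of the same kind, while a 1.9-fold lower number from compound 1 to compound 2 (0.29 log units; within the scatter) stays within the scatter. These steps show that changes on this ring move the number only modestly, in either direction, and give no direct guide for nitro. Compound 4 is therefore expected to stay close to compound 1, with a 1.1-fold lower number from compound 1 to compound 4 (0.04 log units; within the scatter) as the estimated step. For compound 4 the estimate is 12000 nM, in a range from 4000 nM to 40000 nM.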

Compound 4, half-maximal inhibitory concentration: 16900 nM
The estimate for compound 4 lay 1.4-fold (0.15 log units) below the measured number, within the range that was stated.
By their numbers in this assay, from the lowest: compounds 2, 1 and 4 (each within the scatter of the next, the first and the last beyond it); then compound 3.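

In this assay, the carbon that carries fluoro in compound 1 also takes nitro, a group of more heavy atoms that brings hydrogen-bond acceptors, with no change beyond the scatter (a 1.3-fold higher number from compound 1 to compound 4 (0.11 log units; within the scatter)). Methyl on that carbon is the substituent that stands apart among these three, since nitro in its place gives a modest step back toward stronger inhibition (a 2.2-fold lower number from compound 3 to compound 4 (0.34 log units; beyond the scatter)), and the 2-bromophenyl compound now stands clear of the 4-nitrophenyl compound by a modest margin (a 2.5-fold higher number from compound 2 to compound 4 (0.40 log units; beyond the scatter)). Nothing shown accounts for why methyl differs here while fluoro and nitro do not. The compounds shown leave open how an amine or a carboxylic acid on this carbon would read. They also leave open whether bromine owes its number to the element or to its place on the ring, as a 4-bromophenyl analogue would show.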